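The source may report more compounds than this note shows. Statements on the series, on what has been measured and on what is new or still open speak of the compounds shown alone.

For the measured compounds named here, compound 1, `CC(C)[C@H](NC(=O)COc1cccc2ccccc12)C(=O)N[C@@H](CC(=O)O)C(=O)COc1ccccc1C(F)(F)F`, is the one compound of this set that has a number in a functional assay with Homo sapiens as the target; a lower number here means a stronger inhibitor, a higher number a weaker inhibitor: in this assay compound 1 gives 17300 nM. Compound 2, `CC(C)[C@H](NC(=O)COc1cccc2ccccc12)C(=O)N[C@@H](CC(=O)O)C(=O)COc1c(F)cccc1F`, sits at a limit of this assay. In this assay compound 2 gives > 100000 nM, which is a limit and not a number. Going by the values given here, the single measured step runs an at least 5.7-fold higher number from compound 1 to compound 2 (0.76 log units; beyond the scatter), a loss that goes beyond the scatter. Compound 3, `CC(C)[C@H](NC(=O)COc1cccc2ccccc12)C(=O)N[C@@H](CC(=O)O)C(=O)COc1cccc(C(F)(F)F)c1F`, differs from compound 1 in 2-fluoro-3-(trifluoromethyl)phenyl in place of 2-(trifluoromethyl)phenyl on an oxygen on a saturated carbon. Among the compounds with values here, only the step from compound 1 to compound 2 bears on this change, and it shows that exchanging the group on that oxygen can push the read-out out to the limit of > 100000 nM in this assay, at which 1 of the 2 values shown sits. Within the data shown here, the group entering in compound 3 keeps a trifluoromethyl and adds one fluorine, so the change is smaller than the one that produced compound 2. She therefore expects for compound 3 a somewhat higher number, a step of a 1.7-fold higher number from compound 1 to compound 3 (0.24 log units; within the scatter), smaller than the measured loss. Her estimate is that compound 3 gives 30000 nM in this assay, within a range from 10000 nM to 100000 nM.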

Compound 3, half-maximal inhibitory concentration: 18200 nM
Compound 3: the middle estimate sits 1.6-fold (0.22 log units) above what was measured; measured number inside the range.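

In this assay, the place on an oxygen on a saturated carbon accepts 2-fluoro-3-(trifluoromethyl)phenyl in place of 2-(trifluoromethyl)phenyl with no change that can be told from the scatter: the step is a 1.1-fold higher number from compound 1 to compound 3 (0.02 log units; within the scatter). The loss seen with 2,6-difluorophenyl therefore does not extend to every exchange of this group, and the step in the other direction is an at least 5.4-fold lower number from compound 2 to compound 3 (0.73 log units; beyond the scatter), so among these compounds the two that carry a trifluoromethyl group have numbers, while compound 2, which has none, does not. The value of compound 2 remains a limit and not a number: the limit of > 100000 nM in this assay, at which 1 of the 3 values shown sits.

The compounds shown do not separate the trifluoromethyl group from the fluorines on the ring, and a phenyl group with a single fluorine, a chlorine or a methoxy group on this oxygen would be needed to tell these apart. As far as these compounds go, it also stays open whether a nitrile on the phenyl ring or a pyridine ring in its place would give a lower number than compound 1, and what a change elsewhere on the shared core, such as at the carboxylic acid, would do.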